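The compounds below may be only part of what the source reports. "The series", "measured", "known", "first", "only" and "open" are said of these compounds alone.

Measured compounds:
- Compound 1, `COc1cc(Cl)cc(-c2nn(-c3cccc(NC(=O)Nc4ccc(Cl)c(C(F)(F)F)c4)c3)cc2-c2ccncc2)c1`, in a functional assay on PC-3 cells (Homo sapiens) for inhibition, read by sulforhodamine B assay, with a stated time of 48 h, tested at 0.01 uM (a higher number here means a weaker effect of the compound at the concentration tested, a lower number a stronger effect), compound 1 gives 94%.
- Compound 2, `COc1cc(Cl)cc(-c2nn(-c3cccc(NC(=O)Nc4ccc(Cl)c(Cl)c4)c3)cc2-c2ccncc2)c1`, in this assay compound 2 gives 96%.
- Compound 3, `COc1cc(Cl)cc(-c2nn(-c3cccc(NC(=O)Nc4cccc(C(F)(F)F)c4)c3)cc2-c2ccncc2)c1`, in this assay compound 3 gives 91%.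

Compound 3 has the lowest of the three numbers, yet the two steps that end at it, a number 3 percentage points lower from compound 1 to compound 3 (within the scatter) and a number 5 percentage points lower from compound 2 to compound 3 (within the scatter), show that all three compounds sit within the usual scatter of one another and none can be called stronger or weaker.

Compound 4, `COc1cc(Cl)cc(-c2nn(-c3cccc(NC(=O)c4cccc(C(F)(F)F)c4)c3)cc2-c2ccncc2)c1`, differs from compound 3 by 3-(trifluoromethyl)phenyl in place of (3-(trifluoromethyl)phenyl)amino on a carbonyl carbon. For the measured compounds named here, the three measured steps, a number 2 percentage points higher from compound 1 to compound 2 (within the scatter), a number 3 percentage points lower from compound 1 to compound 3 (within the scatter) and a number 5 percentage points lower from compound 2 to compound 3 (within the scatter), all concern the aromatic substituents and none touches the carbonyl and its neighbours, so no measured step bears directly on this change. With every measured step lying within the scatter, the expectation for compound 4 is a step of a number 3 percentage points higher from compound 3 to compound 4 (within the scatter), that is, no change beyond the scatter. Compound 4 is therefore estimated at 94%, within a range from 86% to 100%.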

Compound 4, a percentage reported as activity, at one concentration (the size of the read-out at that concentration, not a potency): 94%
The estimate for compound 4 equals the measured number at the digits printed; measured number inside the range.
By their numbers in this assay, from the lowest: compounds 3, 1, 4 and 2 (each within the scatter of the next).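

Replacing (3-(trifluoromethyl)phenyl)amino with 3-(trifluoromethyl)phenyl on the carbonyl carbon is the first change shown at the link itself rather than among the aromatic substituents, and it removes a nitrogen with its hydrogen, yet this assay records a number 3 percentage points higher from compound 3 to compound 4 (within the scatter). The two wider replacements, which also alter the aromatic substituents, read the same way, with a number 2 percentage points lower from compound 2 to compound 4 (within the scatter) and no change at the digits printed from compound 1 to compound 4 (within the scatter). At the single concentration tested, this position therefore accepts either the amino-linked or the directly attached aryl group without a readable difference, and no supporting data offer an explanation for this.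

Whether the carbonyl itself matters remains open, as the compounds shown do not include a sulfonyl group or a methylene group at that place. A longer chain between the carbonyl and the aromatic ring also remains untested in the compounds shown.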